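Methyl on the six-membered ring of the fused core

The compounds below may be only part of what the source reports. "The series", "measured", "known", "first", "only" and "open" are said of these compounds alone.

Compound 1 `Nc1nc(-c2ccccc2)c(C(=O)c2cnc3ccccn23)s1` in a functional assay on the whole organism (strain Sprague-Dawley) for inhibition, with Rattus norvegicus as the target, read by paw edema, with stated times of 1 h and 3 h, at a dose of 50 mg/kg by the oral route (on this read-out higher numbers stand for more inhibition at the one dose given (going by the name of the read-out) and lower numbers for less inhibition), gives 40%. Compound 2 `Cc1cccn2c(C(=O)c3sc(N)nc3-c3ccccc3)cnc12` gives 20%; the change is methyl in place of hydrogen on an aromatic carbon, and the step is a number 20 percentage points lower from compound 1 to compound 2 (beyond the scatter). Compound 3 `Nc1ncc(C(=O)c2cnc3ccccn23)s1` gives 33%; the change from compound 1 is hydrogen in place of phenyl on an aromatic carbon, and the step is a number 7 percentage points lower from compound 1 to compound 3 (within the scatter).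

Compound 4 `Cc1ccn2c(C(=O)c3cnc(N)s3)cnc2c1` is not yet measured in this assay. From compound 3 the change is methyl in place of hydrogen on an aromatic carbon. The two cores differ by hydrogen in place of phenyl on an aromatic carbon, that is by phenyl against hydrogen on the five-membered ring. The places of the methyl are not the same: in compound 2 it sits ortho to a fused ring, two atoms from the ring nitrogen and meta to a fused ring, whereas in compound 4 it sits meta to a fused ring, opposite the ring nitrogen and para to a fused ring. So this is the same kind of change, not the same change.

The expected step from compound 3 is a number 13 percentage points lower from compound 3 to compound 4 (beyond the scatter), set beside a number 20 percentage points lower from compound 1 to compound 2 (beyond the scatter) but tempered, since the place and the core both differ. Compound 4 is expected to give about 20%, between 5% and 35%.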

Compound 4, a percentage reported as inhibition, in the whole organism at one dose (the size of the read-out at that dose, not a potency): 77%
Compound 4: middle estimate off by 57 percentage points, on the low side; measured number outside the range, above it.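

In this assay, methyl in place of hydrogen on an aromatic carbon gives a number 44 percentage points higher from compound 3 to compound 4 (beyond the scatter), and the direction of this change does not hold across the two pairs: the same change on two cores in this assay, a number 20 percentage points lower (beyond the scatter) from compound 1 to compound 2 and a number 44 percentage points higher (beyond the scatter) from compound 3 to compound 4, 64 percentage points apart, beyond the scatter of two such steps

A step measured on one core is therefore a poor guide to the same kind of change on the other, at least when the methyl also sits in a different place. The result does not show which difference matters, since the two pairs differ both in the place of the methyl and in phenyl against hydrogen on the five-membered ring, and no pair shown separates the two.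

As far as these compounds go, it remains open whether a methyl opposite the ring nitrogen would also give a higher number on the core of compound 1, which carries the phenyl. Also open, from the compounds shown here alone, is whether a methoxy group or a longer chain at that place would match compound 4 at 77%.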